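A Halogen Swap Where Neither Parent Shows Activity

The source may report more compounds than this note shows. Statements on the series, on what has been measured and on what is new or still open speak of the compounds shown alone.

Compound 1 `Cc1nn(C)c(Oc2ccc(F)cc2)c1/C=N\CCCCCOc1cc2oc(=O)cc(C)c2cc1Cl` and compound 2 `Cc1nn(C)c(Oc2cccc(F)c2F)c1/C=N\CCCCCCOc1cc2oc(=O)cc(C)c2cc1Cl` share a core and differ in the aryl ether and in the length of the chain that links the two parts. In a functional assay on HepG2 cells (Homo sapiens) for antiproliferative activity, read by MTT assay, with a stated time of 72 h (a higher number here means a weaker inhibitor, a lower number a stronger inhibitor), compound 1 gives only a limit, > 25000 nM, and no number. Compound 2 likewise reaches only the limit of > 25000 nM in this assay. the limit of > 25000 nM in this assay, at which 2 of the 2 values shown sit, marks where both recorded values stand, so compound 2 sits at the same edge of the assay as its companion, with nothing to rank it by.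

Compound 3 `Cc1nn(C)c(Oc2cccc(Cl)c2)c1/C=N\CCCCCCOc1cc2oc(=O)cc(C)c2cc1Cl` is drawn from compound 2 by 3-chlorophenyl in place of 2,3-difluorophenyl on an oxygen on an aromatic ring. Within the data shown here, no measured pair isolates this change, and with both known values at the limit there is no gradient to extrapolate from. The step from compound 2 to compound 3 is therefore expected to be a step that the limit leaves unreadable from compound 2 to compound 3, nothing beyond the scatter. Compound 3 is accordingly expected to give 40000 nM in this assay, most likely again reported as a limit, within 12000 nM to 150000 nM.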

Compound 3, half-maximal inhibitory concentration: 6220 nM
Beside the measured number, compound 3's estimate is 6.4-fold (0.81 log units) above it, and the stated range ends above it.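

The aryl ether on this oxygen turns out to be a place where activity can be read: with the chain unchanged, 3-chlorophenyl in place of 2,3-difluorophenyl gives an at least 4.0-fold lower number from compound 2 to compound 3 (0.60 log units; beyond the scatter) in this assay. Compound 3 thus moves off the edge of the assay and supplies a number, which the earlier pair could not do. The step is a bound and not a full size, as the value of compound 2 is only a limit: the limit of > 25000 nM in this assay, at which 2 of the 3 values shown sit.

Going by these compounds, how much of the step belongs to the chlorine and how much to the removal of the two fluorines remains open. Also open, on these data alone, is whether 3-bromophenyl or 3-methoxyphenyl on the same oxygen, or a longer chain, would move the number further.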